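This account rests on a few compounds, and the source may have more. Where it says the series, first, only, none or still open, it means among the compounds named here.

Working notes on the series. In a functional assay on BGC-823 cells (Homo sapiens) for inhibition, read by MTT assay, with a stated time of 72 h (on this read-out higher numbers stand for weaker inhibition and lower numbers for stronger inhibition), compound 1 `Cc1cc(N2CC[C@@H](C)[C@@H](N(C)c3ncnc4[nH]ccc34)C2)n2nc(SCc3ccccc3Br)nc2n1` gives 81100 nM, compound 2 `Cc1cc(N2CC[C@@H](C)[C@@H](N(C)c3ncnc4[nH]ccc34)C2)n2nc(SCc3ccc(F)c(Cl)c3)nc2n1` gives 98900 nM, and compound 3 `Cc1ccc(CSc2nc3nc(C)cc(N4CC[C@@H](C)[C@@H](N(C)c5ncnc6[nH]ccc56)C4)n3n2)cc1` gives 69500 nM. Compound 3 therefore stands within the scatter of both other compounds, as shown by a 1.2-fold lower number from compound 1 to compound 3 (0.07 log units; within the scatter) and a 1.4-fold lower number from compound 2 to compound 3 (0.15 log units; within the scatter).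

Compound 4 `Cc1cc(N2CC[C@@H](C)[C@@H](N(C)c3ncnc4[nH]ccc34)C2)n2nc(SCc3ccc(Br)cc3)nc2n1` has 4-bromobenzyl in place of the 4-methylbenzyl of compound 3: bromo in place of methyl on an aromatic carbon. The change lies on an aromatic carbon of a six-membered aromatic ring of carbon only, para to a large group.

Within the data shown here, no measured pair isolates this exchange. The closest evidence comes from the three changes to the aryl group among compounds 1, 2 and 3. The step between compounds 1 and 3 also brings bromo and methyl into the comparison, though in different aryl groups. The remaining step, a 1.2-fold higher number from compound 1 to compound 2 (0.09 log units; within the scatter), also stays within the scatter.

No step beyond the scatter is therefore expected in this assay. The expected step is a 1.2-fold higher number from compound 3 to compound 4 (0.06 log units; within the scatter). Compound 4 is estimated at 80000 nM, with an expected range of 45000 nM to 140000 nM.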

Compound 4, half-maximal inhibitory concentration: 28000 nM
Beside the measured number, compound 4's estimate is 2.9-fold (0.46 log units) above it; the whole stated range lies above it.
By their numbers in this assay, from the lowest: compound 4; then compounds 3, 1 and 2 (each within the scatter of the next).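

In this assay, among these compounds, the exchange of methyl for bromo on an aromatic carbon, para to a large group, gives the first step beyond the scatter (a 2.5-fold lower number from compound 3 to compound 4 (0.39 log units; beyond the scatter)), so this place responds to a single-atom change although the earlier aryl changes all stayed within the scatter. The placing of the bromo also counts, as 4-bromophenyl in place of 2-bromophenyl gives a 2.9-fold lower number from compound 1 to compound 4 (0.46 log units; beyond the scatter) and 4-bromophenyl in place of 3-chloro-4-fluorophenyl gives a 3.5-fold lower number from compound 2 to compound 4 (0.55 log units; beyond the scatter), which leaves compound 4 as the most potent of the four. Nothing available accounts for this gain.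

Going by these compounds, whether methoxy, an amine or a carboxylic acid at the same place would follow bromo or methyl remains open. Also open, on these data alone, is how a longer chain on the sulfur, carrying the same 4-bromophenyl, would read.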